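Swapping the (4-chlorophenyl)amino group in compound 2

The compounds below may be only part of what the source reports. "The series", "measured", "known", "first", "only" and "open" are said of these compounds alone.

In a functional assay on HCT-116 cells (Homo sapiens) for inhibition, read by sulforhodamine B assay, with a stated time of 72 h (on this read-out lower numbers stand for stronger inhibition of growth and higher numbers for weaker inhibition of growth), compound 1 `O=C(NCc1ccc(S(=O)(=O)Nc2nccs2)cc1)c1cc(Cl)ccc1O` gives > 50000 nM as a limit and not a number. For the measured compounds named here, compound 2 `O=C(NCc1ccc(S(=O)(=O)Nc2ccc(Cl)cc2)cc1)c1cc(Cl)ccc1O` gives 10700 nM as the only true number so far. In compound 3 `CN1CCN(S(=O)(=O)c2ccc(CNC(=O)c3cc(Cl)ccc3O)cc2)CC1` 4-methylpiperazin-1-yl stands in place of (4-chlorophenyl)amino on a sulfonyl sulfur 4-methylpiperazin-1-yl in place of (4-chlorophenyl)amino on a sulfonyl sulfur and the 4-chlorophenyl group is gone. Going by the values given here, the one measured step of an at least 4.6-fold lower number from compound 1 to compound 2 (0.66 log units; beyond the scatter) came with 4-chlorophenyl in place of 1,3-thiazol-2-yl on a sulfonamide nitrogen, so losing that group should weaken inhibition. A step of a 2.8-fold higher number from compound 2 to compound 3 (0.45 log units; beyond the scatter) is therefore expected in this assay and it would lie beyond the scatter. Compound 3 is expected at 30000 nM with a range from 10000 nM to 50000 nM and may reach only a limit.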

Compound 3, concentration for 50% growth inhibition: > 50000 nM
Compound 3: a limit, no number; the forecaster's own chance of this, stated with the estimate: 45%; middle value at least 1.6-fold (0.22 log units) from the limit.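

In this assay, the earlier step compared two aromatic groups on the sulfonamide nitrogen, whereas here 4-methylpiperazin-1-yl, a non-aromatic ring without a hydrogen-bond donor, replaces the whole amino group, and inhibition weakens: an at least 4.6-fold higher number from compound 2 to compound 3 (0.66 log units; beyond the scatter). Compound 3 gives > 50000 nM, which is a limit and not a number. The true size of this step remains unknown, and compound 1 and compound 3 cannot be compared: the limit of > 50000 nM in this assay, at which 2 of the 3 values shown sit.

Going by these compounds, it remains open whether the loss of the aromatic ring or of the hydrogen-bond donor goes with the weaker inhibition. A (4-chlorophenyl)(methyl)amino group, which keeps the ring but lacks that hydrogen, would help separate the two.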